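Amino for hydrogen on two benzyl cores: growth inhibition notes

The source may report more compounds than this note shows. Statements on the series, on what has been measured and on what is new or still open speak of the compounds shown alone.

Measured so far:
- compound 1 `ClCc1ccc(Cn2cnc3c(Cl)ncnc32)cc1`: in a functional assay on COLO 205 cells (Homo sapiens) for cytotoxicity, read by sulforhodamine B assay, with a stated time of 48 h (on this read-out lower numbers stand for stronger inhibition of growth and higher numbers for weaker inhibition of growth), compound 1 gives 2230 nM
- compound 2 `Nc1nc(Cl)c2ncn(Cc3ccc(CCl)cc3)c2n1`: compound 2 gives 3630 nM
- compound 3 `ClCc1ccccc1Cn1cnc2c(Cl)ncnc21`: compound 3 gives 3890 nM

Compound 1 and compound 2 share one core and differ by a single change: amino in place of hydrogen on an aromatic carbon. The step this made in this assay is a 1.6-fold higher number from compound 1 to compound 2 (0.21 log units; within the scatter), so on this read-out the pair does not separate beyond the usual scatter.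

Compound 3 is built from the same atoms as compound 1, joined differently; the difference between the two cores is not broken down here. Within the data shown here, its value sits close to those of compound 1 and compound 2, and none of the three pairs separates beyond the scatter, so no compound of the three can be called stronger or weaker than another.

Compound 4 `Nc1nc(Cl)c2ncn(Cc3ccccc3CCl)c2n1` has not yet been measured in this assay. It differs from compound 3 by amino in place of hydrogen on an aromatic carbon, the same change as from compound 1 to compound 2, and the surroundings of the place are described in the same words for both pairs. Among the measured compounds shown here, only one example of this change is available, so the expectation rests on that single step, a 1.6-fold higher number from compound 1 to compound 2 (0.21 log units; within the scatter), carried over to the core of compound 3. Compound 4 is therefore expected to lie at about a 1.5-fold higher number from compound 3 to compound 4 (0.19 log units; within the scatter) relative to compound 3, with the same wide uncertainty. The estimate for compound 4 is 6000 nM, with a likely range from 3000 nM to 12000 nM.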

Compound 4, concentration for 50% growth inhibition: 5010 nM
Estimate against measurement, compound 4: 1.2-fold (0.08 log units) above, and the stated range covers the measured number.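

In this assay, amino in place of hydrogen on an aromatic carbon, here between two ring nitrogen atoms, gives a 1.3-fold higher number from compound 3 to compound 4 (0.11 log units; within the scatter). Set beside the earlier step, the change reads alike on the two cores, with no difference between them that can be told apart from the scatter: the same change on two cores in this assay, a 1.6-fold higher number (0.21 log units; within the scatter) from compound 1 to compound 2 and a 1.3-fold higher number (0.11 log units; within the scatter) from compound 3 to compound 4, 1.3-fold (0.10 log units) apart, within the scatter of two such steps This shows only that, on these two cores, the change leaves the number within the scatter and that the single earlier step was a fair guide for the core of compound 3; it does not show that amino weakens growth inhibition, nor that the same would hold on any core beyond these two.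

The four compounds leave open whether any other group at this place, such as methyl, methoxy or dimethylamino, would move the number beyond the scatter, given that hydrogen and amino do not separate here. Also open, from the compounds shown here alone, is what would follow if the chloro group gave way to a cyclic amine such as morpholine, or the chloromethyl group to hydroxymethyl, as each of the four compounds carries both the chloro and the chloromethyl group.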